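Sulfonyl Substituent Variation and Rat Microsomal Stability

The compounds below may be only part of what the source reports. "The series", "measured", "known", "first", "only" and "open" are said of these compounds alone.

Measured compounds:
compound 1 `O=C(NS(=O)(=O)c1ccccc1)c1ccc(Nc2nc(NC3(c4ccc(Cl)cc4)CC3)nc(OCC(F)(F)F)n2)cc1` gives 100% in an ADME assay on microsomes from liver (Rattus norvegicus) for metabolic stability, with a stated time of 10 min; on this read-out higher numbers stand for a more stable compound and lower numbers for a less stable compound
compound 2 `CCS(=O)(=O)NC(=O)c1ccc(Nc2nc(NC3(c4ccc(Cl)cc4)CC3)nc(OCC(F)(F)F)n2)cc1` gives 85% in this assay
compound 3 `CS(=O)(=O)NC(=O)c1ccc(Nc2nc(NC3(c4ccc(Cl)cc4)CC3)nc(OCC(F)(F)F)n2)cc1` gives 85% in this assay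

Among the compounds with values here, compound 2 stands level with compound 3 in this assay, and together they are the lowest of the three numbers; the only value above them is that of compound 1, the step being a number 15 percentage points lower from compound 1 to compound 2 (beyond the scatter). Compound 4 `CN(C)S(=O)(=O)NC(=O)c1ccc(Nc2nc(NC3(c4ccc(Cl)cc4)CC3)nc(OCC(F)(F)F)n2)cc1` differs from compound 2 in one place: dimethylamino in place of ethyl on a sulfonyl sulfur. Within the data shown here, two measured steps bear on this change. Going from phenyl to a small group on the sulfonyl sulfur gave a number 15 percentage points lower from compound 1 to compound 2 (beyond the scatter) and a number 15 percentage points lower from compound 1 to compound 3 (beyond the scatter), while exchanging one small group for another gave no change at the digits printed from compound 2 to compound 3 (within the scatter). The step to compound 4 is again an exchange between small groups on the sulfonyl sulfur, so in this assay no step beyond the scatter is expected; the expected step is no change at the digits printed from compound 2 to compound 4 (within the scatter). Compound 4 is therefore estimated at 85% in this assay, with an expected range from 70% to 100%.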

Compound 4, percent of the compound remaining: 76%
Compound 4: middle estimate off by 9 percentage points, on the high side, within the range that was stated.
By their numbers in this assay, from the lowest: compounds 4, 2 and 3 (each within the scatter of the next); then compound 1.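

Compound 4 places dimethylamino, bound through nitrogen, on the sulfonyl sulfur, where compounds 1 to 3 carry only carbon-bound groups. In this assay this exchange gives a number 9 percentage points lower from compound 2 to compound 4 (within the scatter) and a number 9 percentage points lower from compound 3 to compound 4 (within the scatter) so ethyl, methyl and dimethylamino cannot be told apart on this read-out. Phenyl remains apart from all three small groups, with a number 24 percentage points lower from compound 1 to compound 4 (beyond the scatter) and no measurement shown offers a reason for these numbers.

From the compounds shown here alone, it remains open whether a longer chain such as butyl or a cyclic amine such as morpholine on the sulfonyl sulfur would stay with the small groups or reach the value of compound 1. Going by these compounds, it is also open whether a pyridine ring in place of phenyl would keep the number of compound 1.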